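Ester chain length and cytotoxicity in one series

The source may report more compounds than this note shows. Statements on the series, on what has been measured and on what is new or still open speak of the compounds shown alone.

Measured so far:
Compound 1 `CCCCCCCCCCOC(=O)CCC(=O)N1CCN(CCCOc2cc3c(Nc4ccc(F)c(Cl)c4)ncnc3cc2OC)CC1` gives 15.5% in a functional assay on A549 cells (Homo sapiens) for cytotoxicity, read by MTT assay, with a stated time of 24 h, tested at 40 uM; on this read-out higher numbers stand for a weaker effect at the one concentration tested and lower numbers for a stronger effect.
Compound 2 `CCCCCCCCCCCCOC(=O)CCC(=O)N1CCN(CCCOc2cc3c(Nc4ccc(F)c(Cl)c4)ncnc3cc2OC)CC1` gives 5.7% in this assay.

In this assay compound 2 holds the lowest of the two numbers, with compound 1 nearest; the separation is a number 9.8 percentage points lower from compound 1 to compound 2 (within the scatter), so no order between the two can be claimed. Compound 3 `CCCCCCCCCCCCCCCCCOC(=O)CCC(=O)N1CCN(CCCOc2cc3c(Nc4ccc(F)c(Cl)c4)ncnc3cc2OC)CC1` carries pentyl in place of hydrogen on a saturated chain carbon, ten or more bonds along the chain from an oxygen next to a carbonyl group. For the measured compounds named here, the only measured step that bears on this change is a number 9.8 percentage points lower from compound 1 to compound 2 (within the scatter), a lengthening of the same chain at the same place that stayed within the scatter; a further lengthening is therefore expected to give no step beyond the scatter in this assay. Compound 3 is expected to give 5%, within a range of 0% to 18%. That estimate means an expected step of a number 0.7 percentage points lower from compound 2 to compound 3 (within the scatter).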

Compound 3, a percentage reported as activity, at one concentration (the size of the read-out at that concentration, not a potency): 85.2%
For compound 3 the middle estimate is 80.2 percentage points below the measured one; measured number above the stated range.
By their numbers in this assay, from the lowest: compounds 2 and 1 (each within the scatter of the next); then compound 3.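

At the saturated chain carbon, added length is not neutral in this assay: pentyl in place of hydrogen gives a number 79.5 percentage points higher from compound 2 to compound 3 (beyond the scatter), and heptyl in place of hydrogen gives a number 69.7 percentage points higher from compound 1 to compound 3 (beyond the scatter), both towards a much weaker effect at the one concentration tested. The ethyl step had stayed within the scatter, so the tolerance seen with compounds 1 and 2 does not extend to compound 3. Nothing available explains this loss.

Still open, as far as these compounds go, is the chain length, between those of compound 2 and compound 3, at which the effect falls away. Also open, from the compounds shown here alone, is whether a longer chain stays as weak, or whether an amine or a carboxylic acid at the chain end changes the outcome.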